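The compounds below may be only part of what the source reports. "The series", "measured", "known", "first", "only" and "open" are said of these compounds alone.

Compound 2 `CC/C=C\C(=O)Nc1cc(Nc2ncc(C#N)c(-c3cn(C)c4ccc(F)cc34)n2)c(OC)cc1N(C)CCN(C)C` gives 4730 nM in a functional assay on A549 cells (Homo sapiens) for antiproliferative activity, read by MTT assay, with a stated time of 72 h (on this read-out higher numbers stand for weaker inhibition and lower numbers for stronger inhibition), the higher of the two numbers at hand, while compound 1 `CCC/C=C\C(=O)Nc1cc(Nc2ncc(C#N)c(-c3cn(C)c4ccccc34)n2)c(OC)cc1N(C)CCN(C)C` gives 166 nM in this assay, a gap well beyond the usual scatter. Compound 3 `CCC/C=C\C(=O)Nc1cc(Nc2ncc(C#N)c(-c3cn(C)c4ccc(F)cc34)n2)c(OC)cc1N(C)CCN(C)C` differs from compound 2 in one place: methyl in place of hydrogen on a saturated chain carbon, two bonds along the chain from a double-bonded chain carbon. Going by the values given here, no measured pair shows this change on its own, so its size is uncertain. For compound 3 a step of a 3.9-fold lower number from compound 2 to compound 3 (0.60 log units; beyond the scatter) toward stronger inhibition is expected in this assay. That expectation rests on compound 1, which carries the same longer chain and gives 166 nM. Compound 3 is expected to give about 1200 nM, between 250 nM and 5000 nM.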

Compound 3, half-maximal inhibitory concentration: 741 nM
For compound 3 the middle estimate is 1.6-fold (0.21 log units) above the measured one; the measured number falls inside the stated range.
By their numbers in this assay, from the lowest: compound 1; then compound 3; then compound 2.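

Going from ethyl to propyl gives a 6.4-fold lower number from compound 2 to compound 3 (0.81 log units; beyond the scatter) in this assay, so a single added methyl on this saturated chain carbon has a real effect with the fluoro group present. Going by these compounds alone, with the propyl chain held fixed, fluoro in place of hydrogen on an aromatic carbon gives a 4.5-fold higher number from compound 1 to compound 3 (0.65 log units; beyond the scatter), which isolates that change for the first time. Nothing measured here explains either step. On these data alone, whether a still longer chain, such as butyl, would lower the number further remains open, as does the effect of a terminal amine on that chain.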